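A few compounds are considered here, and "the series" means these few. Any claim that something is new, unique, unknown or untested is made for them only; others in the source may bear on it.

Measured so far:
- compound 1 `COc1cc(/C=C/C(=O)/C=C(/C=C/c2ccc(O)c(OC)c2)NCCO)ccc1O`: 87200 nM
- compound 2 `COCCNC(=C\C(=O)/C=C/c1ccc(O)c(OC)c1)/C=C/c1ccc(O)c(OC)c1`: > 100000 nM (a limit)

In a functional assay on Caco-2 cells (Homo sapiens) for cytotoxicity, read by MTT assay, with a stated time of 48 h (a higher number here means a weaker inhibitor, a lower number a stronger inhibitor), compound 2 is known only as a limit, > 100000 nM. It therefore has no exact value from which to count a step.

Compound 3 `COCCCNC(=C\C(=O)/C=C/c1ccc(O)c(OC)c1)/C=C/c1ccc(O)c(OC)c1` has not yet been measured. It differs from compound 2 by methoxymethyl in place of methoxy on a saturated chain carbon, two bonds along the chain from an amine nitrogen. The change reads (2-methoxyethyl)amino to (3-methoxypropyl)amino.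

Among the compounds with values here, one measured step bears on this change: an at least 1.1-fold higher number from compound 1 to compound 2 (0.05 log units; that floor lies within the scatter). That step gives only a floor, so no step beyond the scatter is expected in this assay, in either direction. The expected step is a step that the limit leaves unreadable from compound 2 to compound 3, an estimate measured against a limit. A further limit is also quite possible for the new compound.

Compound 3 is expected at 110000 nM, with an estimated range of 60000 nM to 200000 nM.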

Compound 3, half-maximal inhibitory concentration in the Caco-2 assay: 49100 nM
For compound 3 the middle estimate is 2.2-fold (0.35 log units) above the measured one; the whole stated range lies above it.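

In the Caco-2 assay, compound 3 gives 49100 nM, an exact value for a methoxy-bearing chain. In the Caco-2 assay, compound 2 offers only a limit, and the change to (3-methoxypropyl)amino can be sized from one side: an at least 2.0-fold lower number from compound 2 to compound 3 (0.30 log units; that floor lies within the scatter). Against the hydroxy-bearing chain of compound 1, the Caco-2 assay shows a 1.8-fold lower number from compound 1 to compound 3 (0.25 log units; within the scatter), so these two compounds are not told apart. In a physicochemical assay for solubility, using the shake flask method, in phosphate buffer, with a stated time of 24 h, at pH 6.8 (on this read-out higher numbers stand for higher solubility and lower numbers for lower solubility), compound 2 gives 12700 nM and compound 3 gives 9660 nM, and the methoxymethyl change likewise stays small: a 1.3-fold lower number from compound 2 to compound 3 (0.12 log units; within the scatter). The step from compound 2 in the cell assay remains a floor because compound 2 is known only as a limit: the limit of > 100000 nM in the Caco-2 assay, at which 1 of the 3 values shown sits.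

An exact value for compound 2 could still place its step to compound 3 beyond the scatter. Also open, as far as these compounds go, is whether a longer chain, or a chain carrying an amine or a carboxylic acid, would move the number in the Caco-2 assay beyond the scatter.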